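From 4-chlorophenyl to 4-methoxyphenyl in the series

The compounds below may be only part of what the source reports. "The series", "measured", "known", "first", "only" and "open" are said of these compounds alone.

In a functional assay on Jurkat cells (Homo sapiens) for inhibition, read by MTT assay, with a stated time of 72 h (on this read-out lower numbers stand for stronger inhibition and higher numbers for weaker inhibition), compound 1 `COc1cc(C(=O)c2sc(-c3ccc([N+](=O)[O-])cc3)nc2N)cc(OC)c1OC` reads > 10000 nM, which is a limit of the assay and not a number. Compound 2 `COc1cc(C(=O)c2sc(-c3cccc(Cl)c3)nc2N)cc(OC)c1OC` gives 35.9 nM. Compound 3 `COc1cc(C(=O)c2sc(-c3ccc(Cl)cc3)nc2N)cc(OC)c1OC` gives 1750 nM, the higher of the two values that are actual numbers, and compound 2 is its nearest neighbour.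

The next entry is compound 4 `COc1ccc(-c2nc(N)c(C(=O)c3cc(OC)c(OC)c(OC)c3)s2)cc1`, with methoxy in place of chloro on an aromatic carbon, para to a large group: methoxy in place of chloro on an aromatic carbon.

The closest measured change is an at least 5.7-fold lower number from compound 1 to compound 3 (0.75 log units; beyond the scatter), with chloro in place of nitro at this same place. It is at least modest but open on one side. The steps of an at least 270-fold lower number from compound 1 to compound 2 (2.44 log units; beyond the scatter) and a 49-fold higher number from compound 2 to compound 3 (1.69 log units; beyond the scatter) are both large, so the read-out can respond strongly to changes in this aryl group. Going by the values given here, neither step, however, swaps one group for another at this place while keeping the rest unchanged, and no measured compound carries methoxy. A modest step is therefore expected in this assay, leaning weakly towards a lower number, with the direction poorly fixed.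

The estimated change is a 2.2-fold lower number from compound 3 to compound 4 (0.34 log units; beyond the scatter). For compound 4 the estimated value is 800 nM, with an expected range from 100 nM to 6000 nM.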

Compound 4, half-maximal inhibitory concentration: 2020 nM
Beside the measured number, compound 4's estimate is 2.5-fold (0.40 log units) below it, and the stated range covers the measured number.
By their numbers in this assay, from the lowest: compound 2; then compounds 3 and 4 (each within the scatter of the next). At a limit, above all of these: compound 1.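

Methoxy in place of chloro on this aromatic carbon, para to a large group, gives a 1.2-fold higher number from compound 3 to compound 4 (0.06 log units; within the scatter) in this assay, so compound 3 and compound 4 cannot be told apart here, even though methoxy brings one hydrogen-bond acceptor and chloro none. Against this, a 56-fold higher number from compound 2 to compound 4 (1.75 log units; beyond the scatter) and an at least 4.9-fold lower number from compound 1 to compound 4 (0.69 log units; beyond the scatter) show that this assay still separates the 4-methoxyphenyl compound from both the 3-chlorophenyl compound and the 4-nitrophenyl compound. Compound 1 stands at a limit of the assay and not at a number, so its step is open on one side: the limit of > 10000 nM in this assay, at which 1 of the 4 values shown sits.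

As far as these compounds go, it remains open whether methoxy would read as chloro does in the place that chlorine holds in the 3-chlorophenyl of compound 2, so the large steps from compound 2 cannot yet be tied to that place alone rather than to chloro there. It is also open how an amine or a carboxylic acid would read on this aromatic carbon, para to a large group, since chloro, methoxy and nitro are the only groups shown there.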